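The source may hold more compounds than are shown below. What is called first, only, known or untested is meant among the compounds shown, and "the series" means these compounds.

In a functional assay on MT2 cells (Homo sapiens) for antiproliferative activity, read by MTT assay, with a stated time of 72 h (on this read-out lower numbers stand for stronger inhibition of growth and higher numbers for weaker inhibition of growth), compound 1 (`O=C(COc1ccc2c(=O)c(-c3ccccc3)coc2c1)Nc1ccc2ccccc2c1`) gives 7680 nM. Compound 2 (`O=C(COc1c(-c2ccccc2)oc2ccccc2c1=O)Nc1ccc(-c2ccccc2)cc1`) gives > 10000 nM, which is a limit. Compound 3 (`O=C(COc1ccc2c(=O)c(-c3ccccc3)coc2c1)Nc1ccccc1`) gives > 10000 nM, also a limit and not a number, so it stands at the limit of > 10000 nM in this assay, at which 2 of the 3 values shown sit. Compound 4 (`COc1ccc(NC(=O)COc2ccc3c(=O)c(-c4ccccc4)coc3c2)cc1`) changes compound 3 in one place, phenyl to 4-methoxyphenyl: methoxy in place of hydrogen on an aromatic carbon. For the measured compounds named here, the only measured step on this part of the molecule is an at least 1.3-fold higher number from compound 1 to compound 3 (0.11 log units; that floor lies within the scatter), and it involves a different group. Going by the values given here, no measured step involves methoxy, so no change beyond the scatter is expected in this assay, in either direction. The expected step is a step that the limit leaves unreadable from compound 3 to compound 4. Compound 4 is estimated at 11000 nM, with an expected range from 5000 nM to 25000 nM.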

Compound 4, concentration for 50% growth inhibition: 4550 nM
For compound 4 the middle estimate is 2.4-fold (0.38 log units) above the measured one, and the stated range ends above it.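

Methoxy on this six-membered aromatic ring, para to a large group, gives the first step on this part of the molecule that is beyond the scatter: an at least 2.1-fold lower number from compound 3 to compound 4 (0.34 log units; beyond the scatter). Against the naphthalen-2-yl group, the 4-methoxyphenyl group shows a 1.7-fold lower number from compound 1 to compound 4 (0.23 log units; within the scatter), so the two are not told apart in this assay. Compound 3 stands at a limit and not a number, so the methoxy step is only a floor: the limit of > 10000 nM in this assay, at which 2 of the 4 values shown sit.

On these data alone, whether a hydroxyl, an amine or a longer ether chain on that same carbon would match methoxy stays open. So does whether the step carries over to the core of compound 2.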